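The source may report more compounds than this note shows. Statements on the series, on what has been measured and on what is new or still open speak of the compounds shown alone.

Measured compounds:
compound 1, `COc1ccc(-c2[nH]c3ccccc3c2/C=C(\C#N)S(=O)(=O)c2ccccc2)cc1`, a limit of > 100000 nM in a functional assay on MCF7 cells (Homo sapiens) for cytotoxicity, read by MTT assay, with a stated time of 96 h; a lower number here means that less compound is needed, a higher number that more compound is needed for the effect
compound 2, `CC(=O)/C(=C/c1c(-c2ccccc2)[nH]c2ccccc12)C(=O)c1ccccc1`, a limit of > 100000 nM in this assay
compound 3, `N#C/C(=C\c1c(-c2ccccc2)[nH]c2ccccc12)C(=O)c1cccs1`, 29000 nM in this assay

Within the data shown here, compound 3 is the only one of the three to give a number in this assay; the other two sit at the limit of > 100000 nM in this assay, at which 2 of the 3 values shown sit, so compound 3 stands alone as the single measured point, and no step between two measured compounds is available for comparison.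

Compound 4, `COCCOC(=O)/C(C#N)=C/c1c(-c2ccccc2)[nH]c2ccccc12`, differs from compound 3 in one place: 2-methoxyethoxy in place of thiophen-2-yl on a carbonyl carbon. Among the measured compounds shown here, no measured pair covers a change of this kind, so the expectation for compound 4 rests only on the value of compound 3 and on the fact that the other two compounds reached only the assay limit.

The step from compound 3 to compound 4 is expected to be modest and, if anything, toward a higher number, close to the edge of the usual scatter: a 1.7-fold higher number from compound 3 to compound 4 (0.24 log units; within the scatter). Compound 4 is therefore estimated at 50000 nM in this assay, with a range from 15000 nM to 200000 nM, and a real chance that only a limit is reported.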

Compound 4, half-maximal effective concentration: 12000 nM
For compound 4 the middle estimate is 4.2-fold (0.62 log units) above the measured one; measured number outside the range, below it.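

Placing 2-methoxyethoxy in place of thiophen-2-yl on a carbonyl carbon gives a 2.4-fold lower number from compound 3 to compound 4 (0.38 log units; beyond the scatter) in this assay. Among these compounds, this is the first step between two measured compounds here, and it shows that an aromatic ring at this position is not needed for a measurable value, since an open chain with no ring gives a modestly lower number. Compound 1 and compound 2 remain limits and add no step: the limit of > 100000 nM in this assay, at which 2 of the 4 values shown sit.

What the compounds shown leave open is whether an amine or a longer ether chain on the same carbonyl carbon would lower the number further. Also open is which part of the 2-methoxyethoxy group accounts for the step, a question that a plain ethoxy group at this place would address.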